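This account rests on a few compounds, and the source may have more. Where it says the series, first, only, none or still open, it means among the compounds named here.

Measured compounds in an assay on isolated protein for inhibition of sulfide:quinone oxidoreductase, mitochondrial (Homo sapiens); on this read-out higher numbers stand for weaker inhibition and lower numbers for stronger inhibition:
compound 1 `COc1nc(-c2ccccc2)cc(-c2ccc(F)cc2)c1C#N`, 25 nM
compound 2 `COCCOc1nc(-c2ccccc2)cc(-c2ccc(F)cc2)c1C#N`, 123 nM
compound 3 `COc1nc(-c2ccccc2)cc(-c2ccncc2)c1C#N`, 541 nM

Compound 1 gives the lowest number of the three, and both other compounds sit beyond the scatter above it. Within the data shown here, the two steps away from compound 1 differ in kind: a 4.9-fold higher number from compound 1 to compound 2 (0.69 log units; beyond the scatter) is a modest change on the alkoxy side of the shared core, whereas a 22-fold higher number from compound 1 to compound 3 (1.34 log units; beyond the scatter) is a large one and is the only exchange of an aryl group for a pyridyl ring measured so far.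

Compound 4 `COc1nc(-c2cccnc2)cc(-c2ccc(F)cc2)c1C#N` is the next compound in the series; the change from compound 1 is pyridin-3-yl in place of phenyl on an aromatic carbon. Among the measured compounds shown here, only the step from compound 1 to compound 3 bears on this, and it was large; compound 4 alters the other aryl group and carries a different pyridyl isomer, so the single precedent is read with caution. A weaker number than compound 1 is expected in this assay, likely short of what compound 3 showed, which would be a 6.0-fold higher number from compound 1 to compound 4 (0.78 log units; beyond the scatter). For compound 4 the estimate in this assay is 150 nM with a range from 40 nM to 600 nM.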

Compound 4, half-maximal inhibitory concentration: 213 nM
Beside the measured number, compound 4's estimate is 1.4-fold (0.15 log units) below it; measured number inside the range.
By their numbers in this assay, from the lowest: compound 1; then compounds 2 and 4 (each within the scatter of the next); then compound 3.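

In this assay, among these compounds, exchanging phenyl for pyridin-3-yl next to the ring nitrogen gives an 8.5-fold higher number from compound 1 to compound 4 (0.93 log units; beyond the scatter), the first reading at this position. Until now, only the 4-fluorophenyl position and the alkoxy side had been probed, so this step shows that the phenyl position also responds to change. Both groups have the same heavy-atom count, so the change is one ring nitrogen in place of a ring carbon, which adds a hydrogen-bond acceptor; no measurement shown here accounts for the step.

Going by these compounds, whether the response depends on where the ring nitrogen sits remains open, as pyridin-2-yl and pyridin-4-yl at this position would test. Also open, on these data alone, is how a phenyl ring carrying a fluorine or an amine would read here.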